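Swapping the Amide Aryl Group While Keeping the Bromophenyl

The compounds below may be only part of what the source reports. "The series", "measured", "known", "first", "only" and "open" are said of these compounds alone.

Compound 2 `COc1cccc(NC(=O)c2c(NCCO)cc(-c3ccc(Br)cc3)oc2=O)c1` and compound 1 `CCOc1ccccc1NC(=O)c1c(NCCO)cc(-c2ccccc2)oc1=O` share one core. In an ADME assay on Huh-7 cells (Homo sapiens) for cytotoxicity, with a stated time of 3 days (on this read-out lower numbers stand for higher toxicity in this test and higher numbers for lower toxicity in this test), compound 2 gives > 20000 nM, which is a limit of the test rather than a number. Compound 1 likewise gives > 20000 nM in this assay, again a limit. Compound 2 therefore stands at the limit of > 20000 nM in this assay, at which 2 of the 2 values shown sit. Compound 3 `CCOc1ccccc1NC(=O)c1c(NCCO)cc(-c2ccc(Br)cc2)oc1=O` differs from compound 2 by 2-ethoxyphenyl in place of 3-methoxyphenyl on an amide-type nitrogen. Among the measured compounds shown here, no measured step of this kind exists, so no change beyond the scatter is expected, with compound 3 expected to stay at the same limit. The estimate for compound 3 is 30000 nM, in the range 10000 nM to 100000 nM. The expected step is a step that the limit leaves unreadable from compound 2 to compound 3.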

Compound 3, half-maximal cytotoxic concentration: > 20000 nM
Compound 3: only a limit was reported; the forecaster's own chance of this, stated with the estimate: 85%; the middle value is on the limit's open side.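

Compound 3, like compound 1 and compound 2, gives only a limit, so neither step to compound 3 can be read: the limit of > 20000 nM in this assay, at which 3 of the 3 values shown sit.

Whether 2-ethoxyphenyl or bromo changes toxicity at all in this assay stays open: none of the compounds shown gives an actual number.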